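Replacing Bromine With Diethylamino on the Ketone-Side Ring

This account rests on a few compounds, and the source may have more. Where it says the series, first, only, none or still open, it means among the compounds named here.

Of the compounds shown here, three sharing one core have been tested in a functional assay on A549 cells (Homo sapiens) for antiproliferative activity, read by MTT assay, with a stated time of 48 h; on this read-out higher numbers stand for weaker inhibition and lower numbers for stronger inhibition. Compound 1 `CCOc1ccc(C(=O)/C=C/c2c(/C=C/c3ccc(OC)cc3)cc(OC)cc2OC)cc1` carries a 4-ethoxyphenyl on the carbonyl carbon and gives 7.5 ug/mL. Compound 2 `COc1ccc(/C=C/c2cc(OC)cc(OC)c2/C=C/C(=O)c2ccc(C)c(C)c2)cc1` carries a 3,4-dimethylphenyl there and gives 0.1 ug/mL. Compound 3 `COc1ccc(/C=C/c2cc(OC)cc(OC)c2/C=C/C(=O)c2ccc(Br)cc2)cc1` carries a 4-bromophenyl and gives 8.3 ug/mL, the highest of the three numbers, though its distance from compound 1 is within the scatter; only compound 2 stands clearly apart, with an 83-fold higher number from compound 2 to compound 3 (1.92 log units; beyond the scatter).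

Compound 4 `CCN(CC)c1ccc(C(=O)/C=C/c2c(/C=C/c3ccc(OC)cc3)cc(OC)cc2OC)cc1` differs from compound 3 in one place: diethylamino in place of bromo on an aromatic carbon.

The step that most resembles this change is a 1.1-fold higher number from compound 1 to compound 3 (0.04 log units; within the scatter), where one heteroatom-bearing group on the same ring position was swapped for bromine with no real effect. The large swings in this series, a 75-fold lower number from compound 1 to compound 2 (1.88 log units; beyond the scatter) and its reverse, came from a differently substituted ring rather than from a single group exchange at this position. On that basis the expected step is modest, a 1.7-fold lower number from compound 3 to compound 4 (0.22 log units; within the scatter), and the value of compound 4 in this assay is estimated at 5 ug/mL, with a plausible range from 1 ug/mL to 25 ug/mL.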

Compound 4, half-maximal inhibitory concentration: 5.4 ug/mL
Beside the measured number, compound 4's estimate is 1.1-fold (0.03 log units) below it; the measured number falls inside the stated range.
By their numbers in this assay, from the lowest: compound 2; then compounds 4, 1 and 3 (each within the scatter of the next).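

The step of a 1.5-fold lower number from compound 3 to compound 4 (0.19 log units; within the scatter) shows that this position accepts diethylamino, at 5 heavy atoms, in place of bromo, at 1 heavy atom, without a change that can be told from the scatter, and the step of a 1.4-fold lower number from compound 1 to compound 4 (0.14 log units; within the scatter) shows the same when diethylamino replaces ethoxy. Bromo, ethoxy and diethylamino therefore all leave the number at about the same level on this core, so three quite different groups at this place now give no separation, where the earlier compounds offered only two. Among the compounds shown here, the one compound that goes against this level is compound 2, and the step of a 54-fold higher number from compound 2 to compound 4 (1.73 log units; beyond the scatter) shows that the new group does not close the gap to its 3,4-dimethylphenyl ring; no measurement here explains why these groups match or why that ring stands apart.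

From the compounds shown here alone, what remains open is whether the low number of compound 2 needs both methyl groups, and a ring carrying a single methyl would help to separate the two possibilities. Going by these compounds, it is also open whether a carboxylic acid or a primary amine at this place would stay level with bromo, ethoxy and diethylamino or would move the number clearly.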